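The source may report more compounds than this note shows. Statements on the series, on what has been measured and on what is new or still open speak of the compounds shown alone.

Working notes on the series. Compound 1 `COc1ccc(-c2[nH]c3ccccc3c2/C=C(\C#N)S(=O)(=O)c2ccccc2)cc1` carries a single methoxy, on the outer phenyl; in a functional assay on SK-MES-1 cells (Homo sapiens) for cytotoxicity, read by MTT assay, with a stated time of 96 h (on this read-out lower numbers stand for an effect already at smaller amounts and higher numbers for an effect only at larger amounts of compound), compound 1 gives 43000 nM. Compound 2 `COc1ccc(-c2[nH]c3ccc(OC)cc3c2/C=C(\C#N)S(=O)(=O)c2ccccc2)cc1` adds a second methoxy on the shared core. In this assay compound 2 reaches only a limit, > 100000 nM, so where compound 2 stands is known from one side alone. The measured step of an at least 2.3-fold higher number from compound 1 to compound 2 (0.36 log units; beyond the scatter) therefore rests on the limit of > 100000 nM in this assay, at which 1 of the 2 values shown sits, and is itself open-ended.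

Compound 3 `COc1ccc2[nH]c(-c3ccccc3)c(/C=C(\C#N)S(=O)(=O)c3ccccc3)c2c1` keeps the core methoxy of compound 2 and drops the other one: hydrogen in place of methoxy on an aromatic carbon, which cut one bond further out reads 4-methoxyphenyl to phenyl. Among the compounds with values here, the only measured step concerns the methoxy entering on the core, not the methoxy leaving here, so no measured step bears directly on this change; the one step recorded is at least modest toward higher numbers. Because compound 2 sits at a limit, the estimate can only be anchored loosely. The estimated step is a number no higher from compound 2 to compound 3 (the limit leaves the size open). Compound 3 is expected near 100000 nM, within 40000 nM to 300000 nM, with a real chance that the assay again reports only a limit.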

Compound 3, half-maximal effective concentration: 12000 nM
Compound 3: middle estimate off by 8.3-fold (0.92 log units), on the high side; measured number below the stated range.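

Within the data shown here, with the core methoxy held in place, the change from 4-methoxyphenyl to phenyl gives an at least 8.3-fold lower number from compound 2 to compound 3 (0.92 log units; beyond the scatter) in this assay, the first reading of what the methoxy on the outer ring does at this position, as the earlier step concerned only the methoxy on the shared core. The outer position, para to a large group, therefore counts in this assay, and here hydrogen goes with the lower number and methoxy with the higher one. Compound 2 stands at a limit, so this step is bounded on one side only and its true size stays open: the limit of > 100000 nM in this assay, at which 1 of the 3 values shown sits.

Open is whether the change from 4-methoxyphenyl to phenyl runs the same way and to a similar extent when the core carries hydrogen instead of methoxy, as the compounds shown hold this step only in the presence of the core methoxy. Also open, from the compounds shown here alone, is how other groups at the same outer position, such as an amine, a carboxylic acid or a longer chain like butoxy, would read in this assay compared with hydrogen and methoxy.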